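Substituent on the aromatic nitrogen: outlook for compound 3

The source may report more compounds than this note shows. Statements on the series, on what has been measured and on what is new or still open speak of the compounds shown alone.

Compound 1 `CN(CCNCc1cn(C(C)(C)C)nn1)CCNc1ccnc2cc(Cl)ccc12` and compound 2 `CN(CCNCc1cn(CCCO)nn1)CCNc1ccnc2cc(Cl)ccc12` share one core and differ only in the group on the aromatic nitrogen. In a functional assay on NCI-H460 cells (Homo sapiens) for antiproliferative activity, read by sulforhodamine B assay, with a stated time of 72 h (on this read-out higher numbers stand for weaker inhibition and lower numbers for stronger inhibition), compound 1 gives 79000 nM. Compound 2 reaches only a limit of the assay in this assay, > 200000 nM. The step of an at least 2.5-fold higher number from compound 1 to compound 2 (0.40 log units; beyond the scatter) shows that this group moves the read-out, and compound 2 sits at the weak end of the pair, as far as the limit of > 200000 nM in this assay, at which 1 of the 2 values shown sits, lets one say. Compound 3 `CN(CCNCc1cn(Cc2nc3ccccc3[nH]2)nn1)CCNc1ccnc2cc(Cl)ccc12` follows from compound 2 by the change (1H-benzimidazol-2-yl in place of 2-hydroxyethyl on a saturated chain carbon bound to an aromatic nitrogen). Among the measured compounds shown here, the only measured step, an at least 2.5-fold higher number from compound 1 to compound 2 (0.40 log units; beyond the scatter), exchanged an alkyl group for a hydroxyalkyl one, so it gives no direct reading for an aromatic group entering at this place. For compound 3 the expected step is an at least 1.6-fold lower number from compound 2 to compound 3 (0.22 log units; that floor lies within the scatter), modest and uncertain in direction. For compound 3 the estimate in this assay is 120000 nM, with a range from 30000 nM to 400000 nM.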

Compound 3, half-maximal inhibitory concentration: 120000 nM
Beside the measured number, compound 3's estimate shows no gap at the digits printed; low and high end bracket the measured number.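

In this assay, (1H-benzimidazol-2-yl)methyl on the aromatic nitrogen gives compound 3 a measured number, whereas 3-hydroxypropyl leaves compound 2 at a limit of the assay. The reading an at least 1.6-fold lower number from compound 2 to compound 3 (0.22 log units; that floor lies within the scatter) therefore does not separate the two groups on its floor alone, and the true size of the step stays unknown: the limit of > 200000 nM in this assay, at which 1 of the 3 values shown sits.

Against tert-butyl the reading is a 1.5-fold higher number from compound 1 to compound 3 (0.18 log units; within the scatter), so compound 1 and compound 3 are not told apart, and this place takes an aromatic ring system without a shift beyond the scatter.

As far as these compounds go, what a plain benzyl group or a carboxylic acid on the aromatic nitrogen would give remains open. Also open, from the compounds shown here alone, is whether any group at this place can bring the series clearly ahead of compound 1.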